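Ethyl for cyclopropyl on the ring-nitrogen side chain

The source may report more compounds than this note shows. Statements on the series, on what has been measured and on what is new or still open speak of the compounds shown alone.

Measured so far in a functional assay for antagonist activity at corticotropin-releasing factor receptor 1 (Rattus norvegicus); a higher number here means a weaker inhibitor, a lower number a stronger inhibitor:
compound 1 `CC[C@H](C1CC1)n1c(=O)c(C)nc2c(-c3cc(F)c(OC)cc3Cl)ccnc21` gives 1.7 nM;
compound 2 `CC[C@H](C1CC1)n1c(=O)c(C)nc2c(-c3cc(F)c(OC)cc3C)ccnc21` gives 9.4 nM;
compound 3 `COCC(C1CC1)n1c(=O)c(C)nc2c(-c3cc(F)c(OC)cc3Cl)ccnc21` gives 1.5 nM.

Compound 3 has the lowest number of the three, but its gap to compound 1 is within the scatter, so the two cannot be ranked against each other; only compound 2 sits apart, with a number beyond the scatter above both. Two steps are known. On the aryl ring, a 5.5-fold higher number from compound 1 to compound 2 (0.74 log units; beyond the scatter). On the side chain at the ring nitrogen, a 1.1-fold lower number from compound 1 to compound 3 (0.05 log units; within the scatter), which shows that this side chain tolerates a rather different group without a shift in this assay.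

Compound 4 `CCC(COC)n1c(=O)c(C)nc2c(-c3cc(F)c(OC)cc3Cl)ccnc21` differs from compound 3 by ethyl in place of cyclopropyl on a saturated chain carbon bound to an aromatic nitrogen and a saturated chain carbon. Among the compounds with values here, no measured pair carries exactly this change. Within the data shown here, the only step that bears on it is the one at the same side chain, and that step stayed within the scatter; the step on the aryl ring does not touch this part of the molecule. On that basis a small shift at most is expected, if any, and the direction is not decided by the data.

For compound 4 the estimate is 3 nM, within 1 nM to 9 nM, which corresponds to an expected step of a 2.0-fold higher number from compound 3 to compound 4 (0.30 log units; within the scatter).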

Compound 4, half-maximal inhibitory concentration: 2.1 nM
The estimate for compound 4 lay 1.4-fold (0.15 log units) above the measured number, and the stated range covers the measured number.
By their numbers in this assay, from the lowest: compounds 3, 1 and 4 (each within the scatter of the next); then compound 2.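

In this assay, ethyl in place of cyclopropyl on a saturated chain carbon bound to an aromatic nitrogen and a saturated chain carbon gives a 1.4-fold higher number from compound 3 to compound 4 (0.15 log units; within the scatter), so with the chloro aryl group and the methoxy-bearing side chain in place, the three-membered ring is not needed to stay in the same range. The side chain of compound 4, 1-(methoxymethyl)propyl, carries no cyclopropyl, and its replacement of 1-cyclopropylpropyl gives a 1.2-fold higher number from compound 1 to compound 4 (0.09 log units; within the scatter), which means that compounds 1, 3 and 4 cannot be ranked against one another even though the cyclopropyl is present in only two of them. No measurement available here offers an explanation for this tolerance at the side chain.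

The compounds shown leave open whether this tolerance extends to a longer chain such as butyl, or to an amine, at the same side chain carbon. Within the data shown here, they also leave open whether ethyl in place of cyclopropyl would behave in the same way with methyl in place of chloro on the aromatic carbon, the one change here that moved the number beyond the scatter.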